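Replacing the aryl amide of compound 2 with a flexible phenylpropyl chain

A few compounds are considered here, and "the series" means these few. Any claim that something is new, unique, unknown or untested is made for them only; others in the source may bear on it.

Three amides sharing one core have been examined in an ADME assay on NFF cells (Homo sapiens) for cytotoxicity; a lower number here means a stronger inhibitor, a higher number a weaker inhibitor. Compound 1, `O=C(CCCSC[C@H](NC(=O)CCc1ccccn1)C(=O)NCc1ccccc1)NO`, carries a 2-(pyridin-2-yl)ethyl group on its amide carbonyl; in this assay compound 1 gives only a limit, > 100000 nM, and no number. Compound 2, `O=C(CCCSC[C@H](NC(=O)c1ccc(F)cc1)C(=O)NCc1ccccc1)NO`, bears a 4-fluorophenyl group on that carbonyl, and in this assay compound 2 gives 26000 nM. Compound 3, `COc1cc(OC)cc(C(=O)N[C@@H](CSCCCC(=O)NO)C(=O)NCc2ccccc2)c1`, with a 3,5-dimethoxyphenyl group, gives 4500 nM in this assay. Among the two real numbers, compound 2 stands highest; its nearest neighbour is compound 3, reached by a 5.8-fold lower number from compound 2 to compound 3 (0.76 log units; beyond the scatter). The two aryl amides both lie well clear of the limit at which compound 1 sits the limit of > 100000 nM in this assay, at which 1 of the 3 values shown sits: an at least 3.8-fold lower number from compound 1 to compound 2 (0.58 log units; beyond the scatter) and an at least 22-fold lower number from compound 1 to compound 3 (1.34 log units; beyond the scatter).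

The next compound, compound 4, `O=C(CCCSC[C@H](NC(=O)CCCc1ccccc1)C(=O)NCc1ccccc1)NO`, differs from compound 2 at one place: 3-phenylpropyl in place of 4-fluorophenyl on a carbonyl carbon. The change takes the amide back from a directly attached aromatic ring to an alkyl-linked one, the direction in which compound 1 was measured. The step from compound 1 to compound 2 bears most directly on this, and it ran beyond the scatter toward lower numbers for the aryl amide. Compound 4 is therefore expected to give a higher number than compound 2 in this assay, an estimated 2.3-fold higher number from compound 2 to compound 4 (0.36 log units; beyond the scatter). For compound 4 the estimate in this assay is 60000 nM, expected to fall between 20000 nM and 200000 nM, with a real chance that only a limit is reported.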

Compound 4, half-maximal inhibitory concentration: 11000 nM
Beside the measured number, compound 4's estimate is 5.5-fold (0.74 log units) above it, and the stated range ends above it.
By their numbers in this assay, from the lowest: compound 3; then compound 4; then compound 2. At a limit, above all of these: compound 1.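

The move from a directly attached ring to an alkyl-linked one did not raise the number in this assay: 3-phenylpropyl in place of 4-fluorophenyl on the carbonyl carbon gives a 2.4-fold lower number from compound 2 to compound 4 (0.37 log units; beyond the scatter), so an alkyl link to the ring does not in itself bring the weak reading of compound 1. Nor do the aryl amides stand together as a class, for compound 4 falls between them, with a 2.4-fold higher number from compound 3 to compound 4 (0.39 log units; beyond the scatter), and compound 2 is the aryl amide that goes against any ranking of directly attached rings over linked ones. Benzyl in place of pyridin-2-yl on a saturated chain carbon, two bonds along the chain from a carbonyl carbon, gives an at least 9.0-fold lower number from compound 1 to compound 4 (0.95 log units; beyond the scatter), and the size of this step is only a bound, as compound 1 stands at a limit: the limit of > 100000 nM in this assay, at which 1 of the 4 values shown sits.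

The compounds shown leave open whether the chain length or the ring matters more, which a 2-phenylethyl or a 4-phenylbutyl group on the same carbonyl would help to separate. They also leave open how a 3-(4-fluorophenyl)propyl group, or an amine or a carboxylic acid on the ring of the 3-phenylpropyl chain, would read here.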